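The source may hold more compounds than are shown below. What is called first, only, known or untested is meant among the compounds shown, and "the series" means these compounds.

In a functional assay on SW-620 cells (Homo sapiens) for antiproliferative activity, read by MTT assay, with a stated time of 24 h (a higher number here means a weaker inhibitor, a lower number a stronger inhibitor), compound 1 `COc1ccc(/C=C/C(=O)c2ccc(OC)c3c2OC(C)(C)C=C3)c(F)c1` gives 6570 nM as a true measured number. Compound 2 `COc1ccc(C(=O)/C=C/c2cccc(F)c2)c2c1C=CC(C)(C)O2` gives > 10000 nM which is a limit of the assay and not a number. Compound 3 `COc1ccc(C(=O)/C=C/c2cccs2)c2c1C=CC(C)(C)O2` gives > 10000 nM which is likewise a limit. Among the compounds with values here, compound 3 therefore has no exact value and stands at the limit of > 10000 nM in this assay, at which 2 of the 3 values shown sit, on the numbers so far.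

Compound 4 `COc1ccc(C(=O)/C=C/c2ccccc2Cl)c2c1C=CC(C)(C)O2` carries 2-chlorophenyl in place of thiophen-2-yl on a double-bonded chain carbon bound to a double-bonded chain carbon.

Within the data shown here, three measured steps bear on this change: an at least 1.5-fold higher number from compound 1 to compound 2 (0.18 log units; that floor lies within the scatter) and an at least 1.5-fold higher number from compound 1 to compound 3 (0.18 log units; that floor lies within the scatter) and also a step that the two limits leave unreadable from compound 2 to compound 3 in the same assay. None of them shows a size beyond the scatter. Compound 2 is the nearest guide, as its 3-fluorophenyl is also a phenyl ring with one halogen, and its > 10000 nM is a limit.

In this assay the expected step is a step that the limit leaves unreadable from compound 3 to compound 4 and nothing beyond the scatter is expected. For compound 4 the estimate is 11000 nM with an expected range from 5500 nM to 22000 nM in this read-out.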

Compound 4, half-maximal inhibitory concentration: > 10000 nM
Compound 4: no number, only a limit; the forecaster's own chance of this, stated with the estimate: 70%; the middle value is on the limit's open side.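

In this assay compound 4 gives > 10000 nM, which is a limit of the assay and not a number. Within the data shown here, the only new step that can be read is an at least 1.5-fold higher number from compound 1 to compound 4 (0.18 log units; that floor lies within the scatter), while the steps linking compound 4 to compound 2 and compound 3 cannot be read. On this double-bonded chain carbon, 2-chlorophenyl thus joins 3-fluorophenyl and thiophen-2-yl as a third group that yields no exact value, and compound 4 stands at: the limit of > 10000 nM in this assay, at which 3 of the 4 values shown sit.

From the compounds shown here alone, how far compound 2, compound 3 and compound 4 lie past that limit stays unknown, so they cannot be ranked, and the printed steps do not show that the 2-fluoro-4-methoxyphenyl of compound 1 gives a real gain. Going by these compounds, whether a phenyl ring carrying an amine or a carboxylic acid at this place would give a readable number also remains open.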